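This account rests on a few compounds, and the source may have more. Where it says the series, first, only, none or still open, it means among the compounds named here.

Measured: compound 1 `Nc1cc(N)c2nc(-c3ccccc3)c(NCc3ccc(F)cc3)nc2c1` and compound 2 `COc1ccc(CNc2nc3cc(N)cc(N)c3nc2-c2ccccc2)cc1`.

In a functional assay on M14 cells (Homo sapiens) for inhibition, read by sulforhodamine B assay, with a stated time of 48 h (a lower number here means that less compound is tolerated, a higher number that more compound is tolerated), compound 2 gives 57500 nM. For compound 1 the read-out in this assay is a limit only, < 100000 nM. The step that the limit leaves unreadable from compound 1 to compound 2 cannot be sized (the limit of < 100000 nM in this assay, at which 1 of the 2 values shown sits).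

Compound 3 `Nc1cc(N)c2nc(-c3ccccc3)c(Sc3ccc(F)cc3)nc2c1` differs from compound 1 by (4-fluorophenyl)sulfanyl in place of (4-fluorobenzyl)amino on an aromatic carbon. Among the measured compounds shown here, no measured step covers this change, and compound 1 itself stands only at a limit, so the expectation rests on the two values shown without a readable trend. The estimated value for compound 3 in this assay is 50000 nM, with a range from 10000 nM to 150000 nM. The expected step that the limit leaves unreadable from compound 1 to compound 3 is uncertain in direction.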

Compound 3, concentration lethal to 50% of the cells: 58900 nM
For compound 3 the middle estimate is 1.2-fold (0.07 log units) below the measured one; the measured number falls inside the stated range.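

No step from compound 1 to compound 3 can be read in this assay, because compound 1 stands only at a limit: the limit of < 100000 nM in this assay, at which 1 of the 3 values shown sits.

Whether (4-fluorophenyl)sulfanyl in place of (4-fluorobenzyl)amino moves the read-out, and in which direction, stays open in the compounds shown.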